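Replacing bromo with 2-cyclopropylethynyl on compound 3

A few compounds are considered here, and "the series" means these few. Any claim that something is new, unique, unknown or untested is made for them only; others in the source may bear on it.

In an ADME assay on TZM cells (Homo sapiens) for cytotoxicity, read by XTT assay, with a stated time of 4 days (on this read-out higher numbers stand for lower toxicity in this test and lower numbers for higher toxicity in this test), compound 1 `Cc1cc(Br)cc(C)c1Oc1ccc([N+](=O)[O-])c(Nc2ccc(C#N)cc2)n1` gives > 45600 nM, which is a limit of the assay and not a number. Compound 3 `Cc1cc(Br)cc(C)c1Oc1ccc(N)c(Nc2ccc(C#N)cc2)n1` gives 15500 nM and compound 2 `Cc1cc(/C=C/C(=O)O)cc(C)c1Oc1ccc([N+](=O)[O-])c(Nc2ccc(C#N)cc2)n1` gives 27800 nM, two numbers within the scatter of each other.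

The next change leads to compound 4 `Cc1cc(C#CC2CC2)cc(C)c1Oc1ccc(N)c(Nc2ccc(C#N)cc2)n1`: 2-cyclopropylethynyl in place of bromo on an aromatic carbon, (2-cyclopropylethynyl in place of bromo on an aromatic carbon).

The closest guide is an at least 1.6-fold lower number from compound 1 to compound 2 (0.21 log units; that floor lies within the scatter), which also replaces bromo at this place, though on the nitro compound and with a different incoming group. The other measured step, an at least 2.9-fold lower number from compound 1 to compound 3 (0.46 log units; beyond the scatter), is amino in place of nitro, a change already carried by compound 3, so it bears on the new step only as background. Within the data shown here, no measured compound carries the 2-cyclopropylethynyl group.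

In this assay, the expected step is a 1.3-fold lower number from compound 3 to compound 4 (0.11 log units; within the scatter), which is not expected to go beyond the scatter. Compound 4 is estimated at 12000 nM, with an expected range of 5000 nM to 32000 nM.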

Compound 4, half-maximal cytotoxic concentration: 7450 nM
For compound 4 the middle estimate is 1.6-fold (0.21 log units) above the measured one; low and high end bracket the measured number.
By their numbers in this assay, from the lowest: compound 4; then compounds 3 and 2 (each within the scatter of the next). At a limit, above all of these: compound 1.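

In this assay this replacement of bromo gives a 2.1-fold lower number from compound 3 to compound 4 (0.32 log units; beyond the scatter) on the amino compounds, so a larger group at this aromatic carbon, para to a large group, goes with higher toxicity in this test for this one pair. The earlier replacement at this place, an at least 1.6-fold lower number from compound 1 to compound 2 (0.21 log units; that floor lies within the scatter) on the nitro compounds, starts from a limit and gives only a floor, whereas the new step has a measured number at both ends. Nothing in hand gives a cause for the new step.

On these data alone, the entering group brings a triple bond and a three-membered ring together, so their shares in the step stay open. Also open, as far as these compounds go, are how a plain ethynyl, a longer alkyl chain or an amine at this place would read, and whether 2-cyclopropylethynyl would give a similar step on the nitro compounds.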